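Diallylamino to piperidin-1-yl on a shared core

The source may hold more compounds than are shown below. What is called first, only, known or untested is meant among the compounds shown, and "the series" means these compounds.

Compound 1 `C=CCN(CC=C)Cc1c(C(F)(F)F)nc2n(-c3c(C)cc(C)cc3C)c(Cl)cn12` carries a diallylamino group on its side chain; in an assay on cells for displacement of a labelled ligand from corticotropin-releasing factor receptor 1 (Homo sapiens), with a stated time of 100 min (on this read-out lower numbers stand for stronger inhibition and higher numbers for weaker inhibition), compound 1 gives 13 nM. Among the three measured compounds this is the second highest number: compound 3 `Cc1cc(C)c(-n2c(Cl)cn3c(CN(CCC(F)(F)F)Cc4ccc(Cl)cc4)c(C(F)(F)F)nc23)c(C)c1` gives 12 nM, a gap within the scatter, whereas compound 2 `Cc1cc(C)c(-n2c(Cl)cn3c(CN(CCC4CC4)CCC(F)(F)F)c(C(F)(F)F)nc23)c(C)c1` gives 110 nM, a gap beyond it. Among the measured compounds shown here, the single measured step, a 9.2-fold lower number from compound 2 to compound 3 (0.96 log units; beyond the scatter), exchanges a substituent on a saturated chain carbon bound to an amine nitrogen, so it concerns the same amine region but not the same exchange. Compound 4 `Cc1cc(C)c(-n2c(Cl)cn3c(CN4CCCCC4)c(C(F)(F)F)nc23)c(C)c1` differs from compound 1 by piperidin-1-yl in place of diallylamino on a saturated chain carbon bound to an aromatic carbon. For the measured compounds named here, no measured step covers this exchange, so only a small weakening is expected for compound 4, a 2.3-fold higher number from compound 1 to compound 4 (0.36 log units; beyond the scatter). The estimate for compound 4 is 30 nM, ranging from 8 nM to 120 nM.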

Compound 4, inhibition constant: 1200 nM
Estimate against measurement, compound 4: 40-fold (1.60 log units) below; measured number above the stated range.
By their numbers in this assay, from the lowest: compounds 3 and 1 (each within the scatter of the next); then compound 2; then compound 4.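

In this assay, piperidin-1-yl in place of diallylamino on a saturated chain carbon bound to an aromatic carbon gives a 92-fold higher number from compound 1 to compound 4 (1.97 log units; beyond the scatter), a large step. Among the compounds shown here, the earlier compounds varied only the substituents of open-chain amines, so this is the first sign that a ring amine at this place can cost far more than the one fewer heavy atom would suggest. No available evidence accounts for the size of this step. As far as these compounds go, it remains open whether the ring itself or the loss of the allyl groups drives the change. A dipropylamino group or a pyrrolidin-1-yl ring at this place could separate the two.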